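The compounds below may be only part of what the source reports. "The series", "measured", "known", "first", "only" and "open" are said of these compounds alone.

Compound 2 `CN1CCN(c2ccc3c(c2)oc(=O)n3C(=O)NCCCCc2ccccc2)CC1` gives 116 nM in an assay on HEK293 cells for inhibition of acid ceramidase (Homo sapiens), read by fluorescence, with stated times of 10 min and 3 h (on this read-out higher numbers stand for weaker inhibition and lower numbers for stronger inhibition), the higher of the two numbers in hand; compound 1 `CN1CCN(c2ccc3c(c2)oc(=O)n3C(=O)NCCCCc2ccccc2)C(=O)C1` gives 52 nM. For the measured compounds named here, the single measured step, a 2.2-fold higher number from compound 1 to compound 2 (0.35 log units; beyond the scatter), bears directly on the change at hand, since compound 3 `CN1CCN(c2ccc3c(c2)oc(=O)n3C(=O)NCCCCc2ccccc2)CC1=O` differs from compound 2 by 4-methyl-3-oxopiperazin-1-yl in place of 4-methylpiperazin-1-yl on an aromatic carbon, so a ring carbonyl returns, though not the one compound 1 carries. The step 1>2 was modest, so a modest movement back toward compound 1 is expected for compound 3, a 1.7-fold lower number from compound 2 to compound 3 (0.22 log units; within the scatter). Compound 3 is therefore estimated at 70 nM, within 30 nM to 160 nM.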

Compound 3, half-maximal inhibitory concentration: 92 nM
The estimate for compound 3 lay 1.3-fold (0.12 log units) below the measured number; the measured number falls inside the stated range.
By their numbers in this assay, from the lowest: compounds 1, 3 and 2 (each within the scatter of the next, the first and the last beyond it).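

In this assay, the 4-methyl-3-oxopiperazin-1-yl group gives a 1.3-fold lower number from compound 2 to compound 3 (0.10 log units; within the scatter), so this ring carbonyl cannot be told apart from the plain 4-methylpiperazin-1-yl group. Against the 4-methyl-2-oxopiperazin-1-yl group it gives a 1.8-fold higher number from compound 1 to compound 3 (0.25 log units; within the scatter), so the two carbonyl placements cannot be told apart either, although the groups of compound 1 and compound 2 do differ beyond the scatter. Nothing available explains this pattern. The compounds shown leave open how a morpholine ring or an open-chain dimethylamino group on this aromatic carbon would read.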